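Amide Substitution on a Butoxy Pyrazole Carboxamide Series

The compounds below may be only part of what the source reports. "The series", "measured", "known", "first", "only" and "open" are said of these compounds alone.

Measured compounds:
compound 1, `CCCCOc1cc(C(=O)NC)nn1-c1ccccc1`, 65%
compound 2, `C=CCNC(=O)c1cc(OCCCC)n(-c2ccccc2)n1`, 4.4%
compound 3, `CCCCOc1cc(C(=O)NCCO)nn1-c1ccccc1`, 61.2%

Three compounds sharing one core were tested in a functional assay on the whole organism (strain Wistar) for inhibition, with Rattus norvegicus as the target, read by paw edema, with stated times of 30 min and 3 h, at a dose of 100 mg/kg by the oral route; a lower number here means less inhibition, a higher number more inhibition at the dose given (going by the name of the read-out). Compound 1 `CCCCOc1cc(C(=O)NC)nn1-c1ccccc1` gives 65%. Compound 2 `C=CCNC(=O)c1cc(OCCCC)n(-c2ccccc2)n1` gives 4.4%, and compound 3 `CCCCOc1cc(C(=O)NCCO)nn1-c1ccccc1` gives 61.2%. Compound 3 thus stands second highest of the three: its nearest neighbour is compound 1, since a number 3.8 percentage points lower from compound 1 to compound 3 (within the scatter), while its furthest is compound 2, since a number 56.8 percentage points higher from compound 2 to compound 3 (beyond the scatter).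

Compound 4 `CCCCOc1cc(C(=O)N(CC)CC)nn1-c1ccccc1` is not yet measured. It differs from compound 3 by diethylamino in place of (2-hydroxyethyl)amino on a carbonyl carbon. The two measured steps at the amide-type nitrogen bear on this: a number 60.6 percentage points lower from compound 1 to compound 2 (beyond the scatter), whereas a number 3.8 percentage points lower from compound 1 to compound 3 (within the scatter). Nothing measured shows what removing the amide hydrogen altogether does. Given one large fall and one flat step at this position, compound 4 is expected to come out lower than compound 3, estimated as a number 31.2 percentage points lower from compound 3 to compound 4 (beyond the scatter). The estimate for compound 4 in this assay is 30%, with a range from 5% to 60%.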

Compound 4, a percentage reported as inhibition, in the whole organism at one dose (the size of the read-out at that dose, not a potency): 44.1%
Compound 4: the middle estimate sits 14.1 percentage points below what was measured, within the range that was stated.
By their numbers in this assay, from the lowest: compound 2; then compound 4; then compounds 3 and 1 (each within the scatter of the next).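

In this assay, an amide without the amide hydrogen still keeps much of the read-out: diethylamino in place of (2-hydroxyethyl)amino on a carbonyl carbon gives a number 17.1 percentage points lower from compound 3 to compound 4 (beyond the scatter), and diethylamino in place of methylamino gives a number 20.9 percentage points lower from compound 1 to compound 4 (beyond the scatter), so both changes cost only a modest part of it. Diethylamino in place of allylamino gives a number 39.7 percentage points higher from compound 2 to compound 4 (beyond the scatter), which shows that the presence of the amide hydrogen does not by itself separate high from low numbers among these compounds, as compound 2 keeps that hydrogen and stands lowest, while compound 4 lacks it and stands above compound 2. No measurement at hand accounts for any of these differences.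

The compounds shown leave open whether the fall to compound 4 goes with the loss of the amide hydrogen or with the size of the two ethyl groups, a question on which ethylamino and dimethylamino on the same carbonyl carbon would bear. They also leave open whether the low number of compound 2 belongs to the vinyl end of allylamino or to the length of the chain, which propylamino in the same place would separate.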